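This account rests on a few compounds, and the source may have more. Where it says the series, first, only, none or still open, it means among the compounds named here.

Measured compounds:

Compound 1, `COc1cccc(S(=O)(=O)c2ccc3c(c2)CCC[C@H]3CN)c1`, in an assay on isolated protein for displacement of a labelled ligand from 5-hydroxytryptamine receptor 6 (Homo sapiens) (on this read-out higher numbers stand for weaker inhibition and lower numbers for stronger inhibition), gives 0.398 nM.
Compound 2, `Cn1ccc(S(=O)(=O)c2ccc3c(c2)CCC[C@H]3CN)c1`, in this assay gives 7.94 nM.
Compound 3, `O=S(=O)(c1cccc(F)c1)c1ccc2c(c1)CCC[C@H]2CN1CC(O)C1`, in this assay gives 0.1 nM.

Among these three, compound 3 stands lowest, and its distance to each of the other two lies beyond the scatter, so within this small set it is the strongest inhibitor. Compound 1 comes nearest to it, and compound 2 lies furthest away.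

Compound 4, `COC(=O)NC[C@@H]1CCCc2cc(S(=O)(=O)c3cccc(F)c3)ccc21`, has not yet been measured in this assay. It differs from compound 3 in one place: (methoxycarbonyl)amino in place of 3-hydroxyazetidin-1-yl on a saturated chain carbon bound to a saturated ring carbon. Among the measured compounds shown here, no pair among the measured compounds shows this change, so nothing measured here tells how large its effect is. For the measured compounds named here, every measured compound carries an amine at that position on the saturated chain carbon, and compound 4 is the first without one; the writer therefore expects a step in this assay toward a higher number, well beyond the scatter, though its size is uncertain. The step from compound 3 to compound 4 is expected to be a 100-fold higher number from compound 3 to compound 4 (2.00 log units; beyond the scatter). For compound 4 the estimate in this assay is 10 nM, with a range from 1 nM to 100 nM.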

Compound 4, inhibition constant: 1.59 nM
For compound 4 the middle estimate is 6.3-fold (0.80 log units) above the measured one; measured number inside the range.
By their numbers in this assay, from the lowest: compound 3; then compound 1; then compound 4; then compound 2.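

Among the compounds shown here, the change on a saturated chain carbon bound to a saturated ring carbon gives a 16-fold higher number from compound 3 to compound 4 (1.20 log units; beyond the scatter) in this assay, the first measured step at this position, and it shows that the group there strongly affects the number. Even so, compound 4 gives 1.59 nM without the ring of the 3-hydroxyazetidin-1-yl group, so a low nanomolar number at this position does not depend on that group. The two groups match in their counts of heavy atoms, donors and acceptors, so those counts alone do not account for the step, and no evidence at hand bears on what lies behind it.

The compounds shown leave open whether a plain dimethylamino group or a piperidine ring at this place would stay close to compound 3. They also leave open whether an acetamide would behave like the (methoxycarbonyl)amino group of compound 4.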